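Hydrazone aryl swap: compound 3 against compound 1

The source may hold more compounds than are shown below. What is called first, only, known or untested is meant among the compounds shown, and "the series" means these compounds.

compound 1 `O=C(CSc1nnc(-c2ccncc2)o1)N/N=C/c1ccc(F)cc1` — 12300 nM
compound 2 `O=C(CSc1nnc(-c2ccncc2)o1)N/N=C/c1cc(Cl)cc(Cl)c1O` — 3260 nM

In a functional assay on HepG2 cells (Homo sapiens) for cytotoxicity, read by MTT assay, with a stated time of 48 h (a lower number here means a stronger inhibitor, a higher number a weaker inhibitor), compound 1 gives 12300 nM, the highest of the two numbers, while compound 2 gives 3260 nM. Going by the values given here, the one measured step, a 3.8-fold lower number from compound 1 to compound 2 (0.58 log units; beyond the scatter), concerns a different change at the same carbon and does not test the present swap. Compound 3 `O=C(CSc1nnc(-c2ccncc2)o1)N/N=C/c1cccs1` differs from compound 1 by thiophen-2-yl in place of 4-fluorophenyl on a carbon with a double bond to nitrogen. Among the compounds with values here, with no measured step bearing on this change, no shift beyond the scatter is expected, and the estimated step is a 1.2-fold lower number from compound 1 to compound 3 (0.09 log units; within the scatter). Compound 3 is estimated at 10000 nM, range 4000 nM to 30000 nM.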

Compound 3, half-maximal inhibitory concentration: 14900 nM
Compound 3: the middle estimate sits 1.5-fold (0.17 log units) below what was measured; the range from low to high includes it.
By their numbers in this assay, from the lowest: compound 2; then compounds 1 and 3 (each within the scatter of the next).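

At the carbon with a double bond to nitrogen, thiophen-2-yl and 4-fluorophenyl cannot be told apart in this assay (a 1.2-fold higher number from compound 1 to compound 3 (0.08 log units; within the scatter)), so the five-membered aromatic ring with 1 hetero atom matches the six-membered aromatic ring of carbon only here. The step from 3,5-dichloro-2-hydroxyphenyl to thiophen-2-yl lies beyond the scatter (a 4.6-fold higher number from compound 2 to compound 3 (0.66 log units; beyond the scatter)), leaving compound 2 with the lowest number of the three. No evidence on the cause of either result is available.

The compounds shown do not separate the chlorines of compound 2 from its hydroxyl. Going by these compounds, what an aminophenyl or a carboxylic acid-bearing phenyl would give at this carbon remains open.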